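A few compounds are considered here, and "the series" means these few. Any claim that something is new, unique, unknown or untested is made for them only; others in the source may bear on it.

Measured compounds and their values:

Compound 1, `CCCCCCn1cnc2c(Nc3ccc(O)cc3)nc(N[C@H]3CC[C@H](N)CC3)nc21`: 5400 nM
Compound 2, `CC(C)CCn1cnc2c(NCc3cccc(Cl)c3)nc(N[C@H]3CC[C@H](N)CC3)nc21`: 3100 nM
Compound 3, `CCCCCCn1cnc2c(Nc3cccc(Cl)c3)nc(N[C@H]3CC[C@H](N)CC3)nc21`: 2300 nM

In a functional assay on K562 cells (Homo sapiens) for inhibition, read by fluorescence, with a stated time of 72 h (a higher number here means a weaker inhibitor of growth, a lower number a stronger inhibitor of growth), compound 3 gives the lowest of the three numbers, although its gap to compound 2 lies within the scatter and only compound 1 sits clearly apart from it. Going by the values given here, the one single-point step among the measured compounds, a 2.3-fold lower number from compound 1 to compound 3 (0.37 log units; beyond the scatter), concerns the group on the aromatic nitrogen, not the chain on the other ring nitrogen. Compound 4, `CC(C)=CCn1cnc2c(Nc3cccc(Cl)c3)nc(N[C@H]3CC[C@H](N)CC3)nc21`, differs from compound 3 at that chain: 2-methylprop-1-en-1-yl in place of pentyl on a saturated chain carbon bound to an aromatic nitrogen. Among the compounds with values here, no measured pair isolates this chain; compound 2 and compound 3 differ both in their chains and in the groups on the amine, so their values show only that the two together leave the numbers within the scatter of each other. With nothing in the data pointing to a shift in either direction, the expected step of no change at the digits printed from compound 3 to compound 4 (within the scatter) is none beyond the scatter. Compound 4 is therefore estimated at 2300 nM in this assay, in a range from 1000 nM to 5500 nM.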

Compound 4, concentration for 50% growth inhibition: 3500 nM
Estimate against measurement, compound 4: 1.5-fold (0.18 log units) below; the measured number falls inside the stated range.
By their numbers in this assay, from the lowest: compounds 3, 2, 4 and 1 (each within the scatter of the next, the first and the last beyond it).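

In this assay, going by these compounds alone, the step at this chain, a 1.5-fold higher number from compound 3 to compound 4 (0.18 log units; within the scatter), isolates the chain for the first time, with the 3-chlorophenyl group on the amine held constant. It shows that exchanging hexyl for 3-methylbut-2-en-1-yl, which brings in a double bond outside aromatic rings, leaves the two compounds within the scatter of each other, so this single pair reveals no dependence on the chain. Nothing available bears on why the two compounds read alike.

The compounds shown leave open what a chain ending in an amine or a carboxylic acid, or a much shorter chain such as methyl, would do on this ring nitrogen. They also leave open whether the same exchange would read alike with the 4-hydroxyphenyl group of compound 1 in place of 3-chlorophenyl.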